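The source may report more compounds than this note shows. Statements on the series, on what has been measured and on what is new or still open speak of the compounds shown alone.

Measured so far:
Compound 1, `O=c1c2ccoc2ccn1[C@@H]1O[C@H](COP(=O)(O)OP(=O)(O)OP(=O)(O)O)[C@@H](O)[C@H]1O`, in a functional assay for agonist activity at P2Y purinoceptor 2 (Homo sapiens), read by FLIPR (on this read-out higher numbers stand for an effect only at larger amounts of compound and lower numbers for an effect already at smaller amounts), gives 68 nM.
Compound 2, `O=c1c2ccsc2ccn1[C@@H]1O[C@H](COP(=O)(O)OP(=O)(O)OP(=O)(O)O)[C@@H](O)[C@H]1O`, in this assay gives 30 nM.

Compound 2 stands at the lower of the two numbers, and the gap to its only neighbor, a 2.3-fold lower number from compound 1 to compound 2 (0.36 log units; beyond the scatter), is modest yet beyond the scatter. Compound 3, `O=c1c2occc2ccn1[C@@H]1O[C@H](COP(=O)(O)OP(=O)(O)OP(=O)(O)O)[C@@H](O)[C@H]1O`, has not been measured. It differs from compound 2 in one place: a group of 10 heavy atoms (7 carbon, 1 nitrogen, 2 oxygen; one five-membered aromatic ring with 1 hetero atom, one six-membered aromatic ring with 1 hetero atom) in place of a group of 10 heavy atoms (7 carbon, 1 nitrogen, 1 oxygen, 1 sulfur; one five-membered aromatic ring with 1 hetero atom, one six-membered aromatic ring with 1 hetero atom), on a saturated ring carbon. The change brings back an oxygen-containing bicyclic group in place of the sulfur-containing one, though with the five-membered ring oriented differently from the group in compound 1. Among the compounds with values here, only one measured step bears on this, a 2.3-fold lower number from compound 1 to compound 2 (0.36 log units; beyond the scatter), which went downward when sulfur entered. Undoing that exchange is therefore expected to push the number back up by a modest amount, estimated as a 2.0-fold higher number from compound 2 to compound 3 (0.30 log units; within the scatter). The expected value for compound 3 in this assay is 60 nM, within a range from 25 nM to 150 nM.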

Compound 3, half-maximal effective concentration: 221 nM
Estimate against measurement, compound 3: 3.7-fold (0.57 log units) below; the measured number lies above the stated range.
By their numbers in this assay, from the lowest: compound 2; then compound 1; then compound 3.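

Swapping sulfur for oxygen does not act as a simple on-off change at this position: the oxygen-containing group in compound 3 does not return the number to that of compound 1, and a 7.4-fold higher number from compound 2 to compound 3 (0.87 log units; beyond the scatter) in this assay is a larger step than the one seen earlier. The groups in compound 1 and compound 3 have identical atom and ring counts, yet a 3.3-fold higher number from compound 1 to compound 3 (0.51 log units; beyond the scatter), so the arrangement of the two fused rings matters here, and not just which atoms are present. No measurement available here accounts for these differences.

From the compounds shown here alone, whether sulfur also gives a lower number with the five-membered ring arranged as in compound 3 remains open. So does the effect of a methyl group or an amine on that ring.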